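Hydrogen for phenyl on the ring nitrogen: compound 3

The source may report more compounds than this note shows. Statements on the series, on what has been measured and on what is new or still open speak of the compounds shown alone.

Measured compounds:
compound 1 `COc1ccc(OC)c(C2CC(c3ccncc3)=NN2)c1`: 13%
compound 2 `COc1ccc(OC)c(C2CC(c3ccccn3)=NN2c2ccccc2)c1`: 27%

In a functional assay on the whole organism (strain Charles Foster albino) for inhibition, with Rattus norvegicus as the target, read by paw edema, with stated times of 30 min and 3 h, at a dose of 50 mg/kg by the oral route (on this read-out lower numbers stand for less inhibition and higher numbers for more inhibition at the one dose given (going by the name of the read-out)), compound 1 gives 13% and compound 2 gives 27%. Compound 2 stands highest of the two numbers; its nearest neighbour is compound 1, which lies lower by a margin beyond the usual scatter. Among the compounds with values here, the two measured compounds differ in more than one place, so no single-change step connects them, and their values show only that the phenyl-bearing, pyridin-2-yl-bearing compound 2 sits above compound 1.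

Compound 3 `COc1ccc(OC)c(C2CC(c3ccccn3)=NN2)c1` is the unmeasured member. Relative to compound 2 the change is hydrogen in place of phenyl on an amine nitrogen in a ring. No measured pair isolates this change, so the expectation rests on the direction shown between compound 1 and compound 2 alone. The step of a number 9 percentage points lower from compound 2 to compound 3 (within the scatter) is expected to be a decrease, of a size at or a little beyond the scatter. In this assay compound 3 is estimated at 18%, within a range from 6% to 32%.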

Compound 3, a percentage reported as inhibition, in the whole organism at one dose (the size of the read-out at that dose, not a potency): 15%
Beside the measured number, compound 3's estimate is 3 percentage points above it; the range from low to high includes it.
By their numbers in this assay, from the lowest: compounds 1 and 3 (each within the scatter of the next); then compound 2.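

In this assay the substituent on the amine nitrogen in the ring now has a step of its own, a number 12 percentage points lower from compound 2 to compound 3 (beyond the scatter) for hydrogen in place of phenyl, so among the pyridin-2-yl compounds the phenyl goes with the higher inhibition at the one dose given. The other single change, pyridin-2-yl in place of pyridin-4-yl on a carbon with a double bond to nitrogen, gives a number 2 percentage points higher from compound 1 to compound 3 (within the scatter) and so does not separate the two pyridine attachments while hydrogen sits on that nitrogen. Nothing measured beyond these inhibition values bears on either step, so neither can be explained.

Still open, going by these compounds, is whether the phenyl step carries over to the pyridin-4-yl compounds, and whether the two pyridine attachments would also read alike with phenyl on the nitrogen. Equally open, on these data alone, is whether an aromatic ring is needed on that nitrogen at all, which a methyl, a cyclohexyl or an acetyl group there could test against the hydrogen and phenyl compounds.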